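This account rests on a few compounds, and the source may have more. Where it says the series, first, only, none or still open, it means among the compounds named here.

Compound 1 `Cc1ccc(CCCN(CC[C@H](N)C(=O)O)C[C@H]2O[C@@H](n3cnc4c(N)ncnc43)[C@H](O)[C@@H]2O)cc1C(N)=O`: 51 nM in an assay on cells for inhibition of Nicotinamide N-methyltransferase (Homo sapiens), read by fluorescence and coupled enzyme assay, with a stated time of 10 min, in the presence of a further agent that is not named here; a higher number here means a weaker inhibitor, a lower number a stronger inhibitor
Compound 2 `Cc1ccc(C#CCN(CC[C@H](N)C(=O)O)C[C@H]2O[C@@H](n3cnc4c(N)ncnc43)[C@H](O)[C@@H]2O)cc1C(N)=O`: 16 nM in this assay

Compound 2 has the lowest number of the two measured. Compound 3 `NC(=O)c1cccc(CCCCN(CC[C@H](N)C(=O)O)C[C@H]2O[C@@H](n3cnc4c(N)ncnc43)[C@H](O)[C@@H]2O)c1` differs from it by a group of 12 heavy atoms (10 carbon, 1 nitrogen, 1 oxygen; one six-membered aromatic ring of carbon only) in place of a group of 12 heavy atoms (10 carbon, 1 nitrogen, 1 oxygen; one six-membered aromatic ring of carbon only), on a saturated chain carbon bound to an amine nitrogen; the triple bond in the chain leaves and a saturated chain enters. Going by the values given here, the one measured step that bears on this is a 3.2-fold lower number from compound 1 to compound 2 (0.50 log units; beyond the scatter), where a saturated chain gave way to one with a triple bond and the number fell. Returning to a saturated chain is therefore expected to raise the number again, by about a 3.1-fold higher number from compound 2 to compound 3 (0.49 log units; beyond the scatter). Compound 3 is estimated at 50 nM, with a range from 18 nM to 150 nM.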

Compound 3, inhibition constant: 840 nM
Estimate against measurement, compound 3: 17-fold (1.23 log units) below, and the stated range ends below it.
By their numbers in this assay, from the lowest: compound 2; then compound 1; then compound 3.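

Compound 3 carries a saturated chain, as compound 1 does, yet a 16-fold higher number from compound 1 to compound 3 (1.22 log units; beyond the scatter) in this assay, so a saturated chain alone does not set the number here. The larger step, a 53-fold higher number from compound 2 to compound 3 (1.72 log units; beyond the scatter), therefore cannot be laid on the lost triple bond alone: compound 3 also lacks the ring methyl of compound 1 and compound 2, and its chain and amide are arranged differently. No measurement here explains the loss.

Which of these differences carries the loss stays open. Also open, on these data alone, is whether a chlorine or an ethyl group in place of the methyl would keep the number low.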